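The source may report more compounds than this note shows. Statements on the series, on what has been measured and on what is new or still open speak of the compounds shown alone.

Measured in a functional assay on HCT-116 cells (Homo sapiens) for cytotoxicity, read by MTT assay; on this read-out higher numbers stand for weaker inhibition and lower numbers for stronger inhibition:
- Compound 1 `Cc1c(O)cc(CCCCC(C)C)oc1=O`: > 200000 nM (a limit)
- Compound 2 `CCC(C)CCCCc1cc(O)c(C)c(=O)o1`: > 200000 nM (a limit)

Compound 2 stands only at a limit, > 200000 nM. Compound 1 also gives only a limit, > 200000 nM. The measurements so far therefore amount to the limit of > 200000 nM in this assay, at which 2 of the 2 values shown sit.

Compound 3 `Cc1c(O)cc(CCCCC(C)[C@H](C)O)oc1=O` is the next compound to be measured. It differs from compound 2 by hydroxy in place of hydrogen on a saturated chain carbon bound to two saturated chain carbons.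

Within the data shown here, the only measured step is a step that the two limits leave unreadable from compound 1 to compound 2, a methyl change on the chain. It has no readable size, so it offers no measure for the hydroxy change. No step beyond the scatter can be expected in this assay, and no direction can be assigned. Another limit is the likeliest outcome.

The expected step is a number no higher from compound 2 to compound 3 (the limit leaves the size open). For compound 3 the estimated value is 200000 nM, with an expected range from 80000 nM to 400000 nM.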

Compound 3, half-maximal inhibitory concentration: > 200000 nM
Compound 3 ended at the assay's limit; the forecaster's own chance of this, stated with the estimate: 80%; the middle value lies on the limit itself.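

Among these compounds, compound 3 gives > 200000 nM, a limit, so no step among compound 1, compound 2 and compound 3 can be read in this assay. The compounds shown leave open whether the methyl or the hydroxy change on the chain alters inhibition at all, with every result resting at one limit: the limit of > 200000 nM in this assay, at which 3 of the 3 values shown sit.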